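Aryl swap on the shared core and predicted kinase binding

The compounds below may be only part of what the source reports. "The series", "measured", "known", "first", "only" and "open" are said of these compounds alone.

The series shares a core in which a fluorinated phenyl ketone bears a propylsulfonamide, and only the aryl group on the bicyclic ring is varied. In an assay for binding affinity to dual specificity mitogen-activated protein kinase kinase 4 (Homo sapiens), read by KINOMEscan, tested at 100 nM (on this read-out lower numbers stand for a stronger effect and higher numbers for a weaker effect at the one concentration tested), compound 1 `CCCS(=O)(=O)Nc1ccc(F)c(C(=O)c2n[nH]c3ncc(-c4cccc(F)c4)cc23)c1F` gives 8.2%, compound 2 `CCCS(=O)(=O)Nc1ccc(F)c(C(=O)c2n[nH]c3ncc(-c4ccc(C)c(C)c4)cc23)c1F` gives 20%, and compound 3 `CCCS(=O)(=O)Nc1ccc(F)c(C(=O)c2n[nH]c3ncc(-c4ccc(C(C)C)cc4)cc23)c1F` gives 17%. Compound 3 stands second highest of the three numbers: its nearest neighbour is compound 2, a number 3 percentage points lower from compound 2 to compound 3 (within the scatter), and its furthest is compound 1, a number 8.8 percentage points higher from compound 1 to compound 3 (within the scatter). Going by the values given here, the only step beyond the scatter is a number 11.8 percentage points higher from compound 1 to compound 2 (beyond the scatter).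

Compound 4 `CCCS(=O)(=O)Nc1ccc(F)c(C(=O)c2n[nH]c3ncc(-c4ccc(Cl)c(C(F)(F)F)c4)cc23)c1F` differs from compound 3 by 4-chloro-3-(trifluoromethyl)phenyl in place of 4-isopropylphenyl on an aromatic carbon. All three measured steps change the same aryl group at the same place, and two of them stay within the scatter while one is modest. He therefore expects a number 2 percentage points lower from compound 3 to compound 4 (within the scatter), a step of no more than modest size and with no direction that the data can settle. Compound 4 is estimated at 15%, between 5% and 35%.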

Compound 4, a percentage reported as activity, at one concentration (the size of the read-out at that concentration, not a potency): 15%
For compound 4 middle estimate and measured number coincide at the digits printed; measured number inside the range.
By their numbers in this assay, from the lowest: compounds 1, 4, 3 and 2 (each within the scatter of the next, the first and the last beyond it).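

Putting 4-chloro-3-(trifluoromethyl)phenyl at this position, with 11 heavy atoms including chlorine and fluorine against the 9 carbon atoms of 4-isopropylphenyl, gives no step beyond the scatter in this assay: the steps are a number 2 percentage points lower from compound 3 to compound 4 (within the scatter), a number 5 percentage points lower from compound 2 to compound 4 (within the scatter) and a number 6.8 percentage points higher from compound 1 to compound 4 (within the scatter). Among the compounds shown, this position therefore accepts an aryl group carrying both chlorine and trifluoromethyl, and compound 4 adds no separation beyond the one already seen between compound 1 and compound 2. No evidence is available on why the read-out holds across this change.

The compounds shown leave open how an aryl group carrying an amine or a carboxylic acid would read at this position. They also leave open whether any change here can give a step larger than the modest one seen so far.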